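Aryl amide variation in the cyclopentyl-substituted series

The source may hold more compounds than are shown below. What is called first, only, known or untested is meant among the compounds shown, and "the series" means these compounds.

Among the compounds with values here, in a functional assay on NCI-H1299 cells (Homo sapiens) for inhibition, read by CCK-8 assay, with a stated time of 72 h, tested at 10 uM (a lower number here means less inhibition of growth, a higher number more inhibition of growth at the concentration tested), compound 2 `CN(C)C(=O)c1cc2cnc(Nc3ccc(NC(=O)C4(C(=O)Nc5cccc(Br)c5)CC4)cc3)nc2n1C1CCCC1` gives 77.5%, the lower of the two numbers so far; compound 1 `CN(C)C(=O)c1cc2cnc(Nc3ccc(NC(=O)C4(C(=O)Nc5ccc(Cl)c(C(F)(F)F)c5)CC4)cc3)nc2n1C1CCCC1` gives 90.4%, and the step of a number 12.9 percentage points lower from compound 1 to compound 2 (beyond the scatter) lies beyond the scatter. Compound 3 `CN(C)C(=O)c1cc2cnc(Nc3ccc(NC(=O)C4(C(=O)Nc5ccc(O)cc5)CC4)cc3)nc2n1C1CCCC1` differs from compound 2 by 4-hydroxyphenyl in place of 3-bromophenyl on an amide-type nitrogen, the same amide-type nitrogen at which compound 1 and compound 2 differ. Within the data shown here, that single step is the only one bearing on the change and was modest; a further modest fall is expected. For compound 3 the expected result in this assay is 62%, with a range from 38% to 82%, meaning an expected step of a number 15.5 percentage points lower from compound 2 to compound 3 (beyond the scatter).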

Compound 3, percent growth inhibition at one concentration: 89.7%
Estimate against measurement, compound 3: 27.7 percentage points below; the measured number lies above the stated range.
By their numbers in this assay, from the lowest: compound 2; then compounds 3 and 1 (each within the scatter of the next).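

At this amide-type nitrogen, the loss seen with 3-bromophenyl does not extend to every other aryl group: in this assay, 4-hydroxyphenyl gives a number 12.2 percentage points higher from compound 2 to compound 3 (beyond the scatter) and a number 0.7 percentage points lower from compound 1 to compound 3 (within the scatter). A ring without halogen or trifluoromethyl, carrying a hydroxyl instead, therefore matches 4-chloro-3-(trifluoromethyl)phenyl here. No supporting data explain this result.

Whether the difference follows the substituent or its place on the ring remains open, since the compounds shown do not include 4-bromophenyl or 3-hydroxyphenyl. As far as these compounds go, how a 4-aminophenyl or 4-carboxyphenyl group would compare is also open.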